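A few compounds are considered here, and "the series" means these few. Any claim that something is new, unique, unknown or untested is made for them only; others in the source may bear on it.

Compound 2 `Cn1ncc(Cl)c1-c1cc(C(=O)N[C@@H]2CN[C@H](CC(=O)NC3CCC3)C[C@H]2c2ccc(Cl)c(Cl)c2)oc1Cl` carries a cyclobutylcarbamoyl group on a saturated chain carbon bound to a saturated ring carbon. Among the measured compounds shown here, in an assay for inhibition of RAC-alpha serine/threonine-protein kinase (Homo sapiens), read by HTRF, with a stated time of 1 h (a lower number here means a stronger inhibitor, a higher number a weaker inhibitor), compound 2 gives 7.98 nM, the higher of the two numbers measured so far. For the measured compounds named here, its only neighbour is compound 1 `Cn1ncc(Cl)c1-c1cc(C(=O)N[C@@H]2CN[C@H](CCn3cncn3)C[C@H]2c2ccc(Cl)c(Cl)c2)oc1Cl`, which differs in that one chain group and gives 4.47 nM; the step of a 1.8-fold higher number from compound 1 to compound 2 (0.25 log units; within the scatter) shows that the exchange at this chain did not move the number beyond the scatter.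

Compound 3 `Cn1ncc(Cl)c1-c1cc(C(=O)N[C@@H]2CN[C@H](CC(=O)NCCO)C[C@H]2c2ccc(Cl)c(Cl)c2)oc1Cl` has not yet been measured. It is reached from compound 2 by a single change (2-hydroxyethyl in place of cyclobutyl on an amide-type nitrogen). Going by the values given here, no measured step touches the amide nitrogen itself; the one step on record, a 1.8-fold higher number from compound 1 to compound 2 (0.25 log units; within the scatter), concerns the same chain but a different position and was small. On that basis the step of a 1.3-fold higher number from compound 2 to compound 3 (0.10 log units; within the scatter) is expected to stay within the scatter, with no clear direction. Compound 3 is therefore estimated to give 10 nM in this assay, with a likely range from 4 nM to 25 nM.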

Compound 3, half-maximal inhibitory concentration: 1.41 nM
For compound 3 the middle estimate is 7.1-fold (0.85 log units) above the measured one; the whole stated range lies above it.
By their numbers in this assay, from the lowest: compound 3; then compounds 1 and 2 (each within the scatter of the next).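

In this assay the amide-type nitrogen of this chain proves to be a place where the number can move: 2-hydroxyethyl in place of cyclobutyl gives a 5.7-fold lower number from compound 2 to compound 3 (0.75 log units; beyond the scatter) and so goes beyond the scatter, whereas the earlier exchange on this chain stayed within it. The (2-hydroxyethyl)carbamoyl group also separates from the (1H-1,2,4-triazol-1-yl)methyl group, with a 3.2-fold lower number from compound 1 to compound 3 (0.50 log units; beyond the scatter) as the step, which makes compound 3 the lowest of the three while the two earlier chain groups remain within the scatter of each other. The change replaces a four-membered carbon ring with an open chain carrying a hydrogen-bond donor and acceptor, but nothing available explains why the number falls.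

The compounds shown leave open whether the step follows the hydroxyl or the loss of the ring, a question that a plain ethyl group on the same nitrogen would help to separate. As far as these compounds go, how a longer chain such as 3-hydroxypropyl, or an amine in place of the hydroxyl, would read in this assay remains open as well.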